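The compounds below may be only part of what the source reports. "The series", "measured", "known", "first", "only" and "open" are said of these compounds alone.

Of the compounds shown here, three built on one shared core have been measured in an assay on isolated protein for binding affinity to metabotropic glutamate receptor 2 (Homo sapiens), read by GTPgammaS binding; on this read-out higher numbers stand for an effect only at larger amounts of compound and lower numbers for an effect already at smaller amounts. Compound 1 `CCCc1c(OCCCCOc2ccc(-c3nn[nH]n3)cc2)ccc(C(C)=O)c1O` gives 348 nM in this assay, and compound 2 `CCCC(=O)c1ccc(OCCCCOc2ccc(-c3nn[nH]n3)cc2)c(C)c1O` gives 304 nM. Compound 3 `CCCc1c(OCCCCOc2ccc(C(=O)O)cc2)ccc(C(C)=O)c1O` gives 1820 nM, which is the highest number of the three, set apart from compound 1 and from compound 2 by gaps that both lie beyond the scatter. For the measured compounds named here, the one measured step that leads to compound 3 is a 5.2-fold higher number from compound 1 to compound 3 (0.72 log units; beyond the scatter), so the exchange of the group on that aromatic carbon moved the number clearly.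

Compound 4 `CCCc1c(OCCCCOc2ccc(C(=O)NS(C)(=O)=O)cc2)ccc(C(C)=O)c1O` differs from compound 3 by methanesulfonamido in place of hydroxy on a carbonyl carbon; cut one bond further out, the same change reads carboxy to (methylsulfonyl)carbamoyl. Going by the values given here, the only measured step that bears on this is the one from compound 1 to compound 3, since it alters the very carboxy group that is now changed again, and its size was modest. Among the compounds with values here, no measured compound carries the entering group, so the expectation rests on that single comparison. Compound 4 is therefore expected to move back toward the number of compound 1, by a step of a 3.0-fold lower number from compound 3 to compound 4 (0.48 log units; beyond the scatter). The estimate for compound 4 is 600 nM, with a range from 200 nM to 2000 nM.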

Compound 4, half-maximal effective concentration: 1040 nM
The estimate for compound 4 lay 1.7-fold (0.24 log units) below the measured number; the measured number falls inside the stated range.
By their numbers in this assay, from the lowest: compounds 2 and 1 (each within the scatter of the next); then compounds 4 and 3 (each within the scatter of the next).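

In this assay, for the compounds shown here, the exchange at this carbonyl carbon gives a 1.8-fold lower number from compound 3 to compound 4 (0.24 log units; within the scatter), so methanesulfonamido, with its sulfur and nitrogen, cannot be told apart from hydroxy here, a comparison the earlier compounds did not offer. Going by these compounds alone, on the aromatic carbon, a 3.0-fold higher number from compound 1 to compound 4 (0.48 log units; beyond the scatter), and together with a 5.2-fold higher number from compound 1 to compound 3 (0.72 log units; beyond the scatter) this means that two different groups in place of 2H-tetrazol-5-yl now each lie beyond the scatter from compound 1, although the earlier compounds held only one such exchange. Nothing at hand gives a reason for either result.

The compounds shown leave open whether a phenyl or a trifluoromethyl group in place of the methyl on the sulfonyl, or a simple primary amide in place of the whole (methylsulfonyl)carbamoyl group, would stay with compound 3 and compound 4 or come closer to compound 1. They also leave open whether carboxy and (methylsulfonyl)carbamoyl would give steps of the same size on the core of compound 2, which carries a butanoyl and a methyl group where compound 1 carries an acetyl and a propyl group.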